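The compounds below may be only part of what the source reports. "The series", "measured", "known", "first", "only" and "open" are said of these compounds alone.

Compound 1 `COC1=C(C)C(=O)/C(=C(O)/C=C/c2cccc(OC)c2)C(=O)C1(C)C` gives the lowest number of the three measured in a functional assay on A-431 cells (Homo sapiens) for cytotoxicity (on this read-out lower numbers stand for an effect already at smaller amounts and higher numbers for an effect only at larger amounts of compound), at 4.5 ug/mL. Compound 2 `COC1=C(C)C(=O)/C(=C(O)/C=C/c2ccc(O)cc2)C(=O)C1(C)C` gives 14.9 ug/mL in this assay, and compound 3 `CCc1ccc(/C=C/C(O)=C2/C(=O)C(C)=C(OC)C(C)(C)C2=O)cc1` gives 12 ug/mL. The steps from compound 1 are a 3.3-fold higher number from compound 1 to compound 2 (0.52 log units; beyond the scatter) and a 2.7-fold higher number from compound 1 to compound 3 (0.43 log units; beyond the scatter), while the step of a 1.2-fold lower number from compound 2 to compound 3 (0.09 log units; within the scatter) keeps compounds 2 and 3 together.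

Compound 4 `COC1=C(C)C(=O)/C(=C(O)/C=C/c2cc(C)cc(C)c2)C(=O)C1(C)C` differs from compound 1 by 3,5-dimethylphenyl in place of 3-methoxyphenyl on a double-bonded chain carbon bound to a double-bonded chain carbon. The two steps that bear on this change are those from compound 1 to compound 2 and to compound 3, both swaps of the aryl group on the same double-bonded chain carbon, and both gave modestly higher numbers. Among the measured compounds shown here, no measured step tells what a 3,5-dimethylphenyl does there. A modest shift toward a higher number, or none beyond the scatter, is therefore expected for compound 4, as a 1.6-fold higher number from compound 1 to compound 4 (0.19 log units; within the scatter). In this assay compound 4 is estimated at 7 ug/mL, with a range from 3 ug/mL to 17 ug/mL.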

Compound 4, concentration for half-maximal effect: 4 ug/mL
Compound 4: the middle estimate sits 1.8-fold (0.24 log units) above what was measured, within the range that was stated.
By their numbers in this assay, from the lowest: compounds 4 and 1 (each within the scatter of the next); then compounds 3 and 2 (each within the scatter of the next).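

In this assay, 3,5-dimethylphenyl can take the place of 3-methoxyphenyl on this double-bonded chain carbon with no change beyond the scatter (a 1.1-fold lower number from compound 1 to compound 4 (0.05 log units; within the scatter)), so the hydrogen-bond acceptor of the methoxy group is not needed to keep this number. The same group also separates from the other two aryl groups (a 3.0-fold lower number from compound 3 to compound 4 (0.48 log units; beyond the scatter); a 3.7-fold lower number from compound 2 to compound 4 (0.57 log units; beyond the scatter)), so among these four compounds the 3-methoxyphenyl and 3,5-dimethylphenyl groups give the lower numbers and the 4-ethylphenyl and 4-hydroxyphenyl groups the higher ones, with no compound going against this. No supporting measurement bears on why this is so.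

As far as these compounds go, whether a plain phenyl, a 3-methylphenyl or a 3-aminophenyl would keep the lower number remains open. So does the outcome for a 4-methoxyphenyl, which would test the same methoxy group in another named position.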